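This account rests on a few compounds, and the source may have more. Where it says the series, first, only, none or still open, it means among the compounds named here.

Measured compounds in a functional assay on MIA PaCa-2 cells (Homo sapiens) for antiproliferative activity, read by MTT assay, with a stated time of 48 h; a higher number here means a weaker inhibitor, a lower number a stronger inhibitor: compound 1 `CCCCCc1nc(N)n(CC(=O)Nc2ccccc2)c1-c1ccccc1Br` gives 40600 nM; compound 2 `CCCCCCc1nc(N)n(CC(=O)Nc2ccccc2)c1-c1ccccc1Br` gives 8600 nM; compound 3 `CCCCCCCc1nc(N)n(CC(=O)Nc2ccccc2)c1-c1ccccc1Br` gives 7900 nM.

Compound 2 stands second highest of the three numbers in this assay; compound 3 lies nearest to it, and compound 1 lies furthest. Compound 4 `Nc1nc(CC2CC2)c(-c2ccccc2Br)n1CC(=O)Nc1ccccc1` differs from compound 2 by cyclopropyl in place of pentyl on a saturated chain carbon bound to an aromatic carbon. Within the data shown here, the steps that bear on this change are the ones that alter the length of the same chain: a 4.7-fold lower number from compound 1 to compound 2 (0.67 log units; beyond the scatter) and a 5.1-fold lower number from compound 1 to compound 3 (0.71 log units; beyond the scatter), both beyond the scatter, while a 1.1-fold lower number from compound 2 to compound 3 (0.04 log units; within the scatter) stays within it. Among the measured compounds shown here, each lengthening of the chain from pentyl lowered the number, so replacing pentyl with the shorter cyclopropyl is expected to move in the other direction and raise the number, by a step roughly like the one from compound 2 back to compound 1, or somewhat larger. Compound 4 is therefore expected to give about 60000 nM in this assay, with a range from 15000 nM to 200000 nM, which corresponds to an expected step of a 7.0-fold higher number from compound 2 to compound 4 (0.84 log units; beyond the scatter).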

Compound 4, half-maximal inhibitory concentration: 6900 nM
The estimate for compound 4 lay 8.7-fold (0.94 log units) above the measured number; measured number outside the range, below it.
By their numbers in this assay, from the lowest: compounds 4, 3 and 2 (each within the scatter of the next); then compound 1.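

In this assay, compound 4 sides with the longer chains: there is a 1.2-fold lower number from compound 2 to compound 4 (0.10 log units; within the scatter) and a 1.1-fold lower number from compound 3 to compound 4 (0.06 log units; within the scatter), both within the scatter, against a 5.9-fold lower number from compound 1 to compound 4 (0.77 log units; beyond the scatter), which is beyond it. At this position, therefore, cyclopropyl in place of pentyl, with three heavy atoms and one three-membered ring entering for five chain carbons, leaves the number unchanged within the scatter, so among these four compounds chain length alone does not set the number, and compound 1 alone stands apart. Nothing available explains this result.

The compounds shown leave open whether the ring itself matters or whether any group of this size would serve, as isobutyl or cyclobutyl might show. Also open, as far as these compounds go, is how an amine or a carboxylic acid at the end of the chain would read here.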